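A few compounds are considered here, and "the series" means these few. Any claim that something is new, unique, unknown or untested is made for them only; others in the source may bear on it.

Compound 1 `C[C@H]1O[C@@H](n2ccc(NC(=O)CC(C)(C)O)nc2=O)CC[C@@H]1O` is a nucleoside-like amide bearing a 2-hydroxy-2-methylpropyl chain on its carbonyl carbon. In a functional assay on HCT-116 cells (Homo sapiens) for cytotoxicity, read by sulforhodamine B assay, with a stated time of 24 h (a higher number here means a weaker inhibitor, a lower number a stronger inhibitor), compound 1 gives only > 20000 nM, which is a limit of the measurement, not a number; it sits at the limit of > 20000 nM in this assay, at which 1 of the 2 values shown sits. Compound 2 `CCC(C)/C=C/C(=O)Nc1ccn([C@H]2CC[C@H](O[C@H]3O[C@H](C)[C@@H](N(C)C)[C@H](O)[C@H]3O)[C@@H](C)O2)c(=O)n1`, a larger relative carrying an amino sugar, gives 890 nM in this assay. Compound 3 `CC(C)C(=O)Nc1ccn([C@H]2CC[C@H](O)[C@@H](C)O2)c(=O)n1` differs from compound 1 by isopropyl in place of 2-hydroxy-2-methylpropyl on a carbonyl carbon. Among the compounds with values here, no measured step covers such a change here. Compound 3 is expected to stay weak, with an estimate of 30000 nM and a range from 10000 nM to 100000 nM.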

Compound 3, half-maximal inhibitory concentration: > 20000 nM
Compound 3: only a limit was reported; the forecaster's own chance of this, stated with the estimate: 80%; the middle value lies beyond the limit too.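

No step from compound 1 to compound 3 can be read, because both values are limits, not numbers: the limit of > 20000 nM in this assay, at which 2 of the 3 values shown sit.

The compounds shown leave open whether isopropyl in place of 2-hydroxy-2-methylpropyl changes the true strength of compound 3 in this assay.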